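The source may hold more compounds than are shown below. What is called first, only, known or untested is meant among the compounds shown, and "the series" means these compounds.

Measured so far in an assay on isolated protein for agonist activity at Bile acid receptor (Homo sapiens), read by TR-FRET, with a stated time of 3 h, in the absence of a further agent; on this read-out lower numbers stand for an effect already at smaller amounts and higher numbers for an effect only at larger amounts of compound:
compound 1 `O=C(O)c1cccc(NC(=O)c2ccc(Oc3ccccc3)cc2)c1` — 97 nM
compound 2 `COc1cccc(C(=O)Nc2cccc(C(=O)O)c2)c1` — 1040 nM
compound 3 `CO/N=C(/COc1ccc(C(=O)Nc2cccc(C(=O)O)c2)cc1)c1ccccc1` — > 10000 nM, a limit of the assay and not a number

Compound 2 holds the highest of the two numbers recorded; the nearest is compound 1, whose number is lower by a margin that lies beyond the usual scatter. Of compound 3 only a limit is known, (the limit of > 10000 nM in this assay, at which 1 of the 3 values shown sits), so no ordering against the other two can be drawn from it.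

Compound 4 `Cc1cccc(COc2cccc(C(=O)Nc3cccc(C(=O)O)c3)c2)c1` is not yet measured. It differs from compound 2 in one place: 3-methylphenyl in place of hydrogen on a saturated chain carbon bound to an oxygen on an aromatic ring.

Going by the values given here, no step between two measured compounds is recorded, so the size of this one rests on the wider picture. Compound 1 shows that an aromatic ring attached through an oxygen on the core is compatible with a low number, 97 nM. Compound 3, carrying a much larger group on the same kind of oxygen, reaches only a limit of this assay. A 3-methylphenyl group added to the methoxy carbon of compound 2 is smaller than the group in compound 3 and closer in size to that in compound 1.

The step from compound 2 to compound 4 is expected to lower the number by a moderate margin, a 3.5-fold lower number from compound 2 to compound 4 (0.54 log units; beyond the scatter). Compound 4 is estimated at 300 nM, with a range from 60 nM to 3000 nM.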

Compound 4, half-maximal effective concentration: 1860 nM
Compound 4: middle estimate off by 6.2-fold (0.79 log units), on the low side, and the stated range covers the measured number.
By their numbers in this assay, from the lowest: compound 1; then compounds 2 and 4 (each within the scatter of the next). At a limit, above all of these: compound 3.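

In this assay, the first step read at this position is a 1.8-fold higher number from compound 2 to compound 4 (0.25 log units; within the scatter). Going by these compounds alone, the change from methoxy to (3-methylbenzyl)oxy therefore adds a 3-methylphenyl on the saturated chain carbon bound to an oxygen on an aromatic ring, with 7 heavy atoms entering and no shift in the number beyond the usual scatter, so this position accepts a group of this size without a readable gain or loss, something no one-place comparison among the earlier compounds could show. Compound 3 alone stands at a limit of the assay, which is not a number: the limit of > 10000 nM in this assay, at which 1 of the 4 values shown sits.

This single step does not show whether any other group at this position would move the number beyond the scatter, for instance a longer chain, an amine or a carboxylic acid in place of the 3-methylphenyl. Within the data shown here, with only one group tested against hydrogen here, it also stays open whether the methyl on that ring contributes anything, and a plain benzyl ether paired with compound 4 would settle that.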